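Cinnamyl piperidine carboxamides: amide substituent variation

The compounds below may be only part of what the source reports. "The series", "measured", "known", "first", "only" and "open" are said of these compounds alone.

Measured compounds:
Compound 1 `CCc1ccc(NC(=O)C2CCN(C/C=C/c3ccccc3)CC2)cc1` gives 11600 nM in a functional assay on MGC-803 cells (Homo sapiens) for inhibition, read by MTT assay, with a stated time of 72 h; a lower number here means a stronger inhibitor, a higher number a weaker inhibitor.
Compound 2 `O=C(Nc1nc2ccc(Br)cc2s1)C1CCN(C/C=C/c2ccccc2)CC1` gives 4380 nM in this assay.

Compound 1 stands at the higher of the two numbers; compound 2 sits at a lower number, beyond the scatter. Compound 3 `O=C(NCc1ccccc1)C1CCN(C/C=C/c2ccccc2)CC1` carries the change benzyl in place of 4-ethylphenyl on an amide-type nitrogen on the shared core. Within the data shown here, no step between measured compounds covers this change, so nothing in the data sets its size; a step of no more than the scatter, in either direction, is expected as a 1.2-fold higher number from compound 1 to compound 3 (0.08 log units; within the scatter). Compound 3 is therefore estimated at 14000 nM, with a range from 5000 nM to 40000 nM.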

Compound 3, half-maximal inhibitory concentration: > 100000 nM
Compound 3: only a limit was reported (the forecaster's own chance of this, stated with the estimate: 10%); at least 7.1-fold (0.85 log units) between middle value and limit.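

Compound 3 gives > 100000 nM in this assay, a limit of the assay and not a number. Benzyl in place of 4-ethylphenyl on the amide-type nitrogen gives an at least 8.6-fold higher number from compound 1 to compound 3 (0.93 log units; beyond the scatter), so this position responds beyond the scatter to a change that keeps one six-membered aromatic ring of carbon only. The step has a lower bound but no upper bound: the limit of > 100000 nM in this assay, at which 1 of the 3 values shown sits.

Open, on these data alone, is whether the loss goes with the ethyl group or with the carbon link to the ring. An unsubstituted phenyl or a 4-ethylbenzyl group on the same nitrogen would separate the two.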